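A few compounds are considered here, and "the series" means these few. Any claim that something is new, unique, unknown or untested is made for them only; others in the source may bear on it.

Within the data shown here, in a functional assay on K562 cells (Homo sapiens) for inhibition, read by trypan blue exclusion, with a stated time of 72 h (on this read-out higher numbers stand for weaker inhibition and lower numbers for stronger inhibition), only two compounds have been measured so far. Compound 1 `Cn1c(=O)c(S(=O)(=O)c2ccc(F)cc2F)cc2cnc(Nc3ccncn3)nc21` gives 30000 nM, and compound 2 `Cn1c(=O)c(S(=O)(=O)c2ccc(F)cc2F)cc2cnc(Nc3ccc4c(c3)CC(=O)N4)nc21` gives 15000 nM. These two values lie within the usual scatter of each other, so compound 2 stands level with compound 1.

The next compound, compound 3 `Cn1ccc2cc(Nc3ncc4cc(S(=O)(=O)c5ccc(F)cc5F)c(=O)n(C)c4n3)ccc21`, keeps the shared core and differs from compound 2 in one group: a group of 10 heavy atoms (9 carbon, 1 nitrogen; one five-membered aromatic ring with 1 hetero atom, one six-membered aromatic ring of carbon only) in place of a group of 10 heavy atoms (8 carbon, 1 nitrogen, 1 oxygen; one five-membered non-aromatic ring with 1 hetero atom, one six-membered aromatic ring of carbon only), on a nitrogen on an aromatic ring. The group that enters is 1-methyl-1H-indol-5-yl.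

Among the measured compounds shown here, only one measured step bears on this, and it sits at the same place, on a nitrogen on an aromatic ring: a 2.0-fold lower number from compound 1 to compound 2 (0.30 log units; within the scatter). That exchange of one group for a quite different one stayed within the scatter. For the measured compounds named here, a single step is thin evidence, and no measured compound carries the entering group. No step beyond the scatter is therefore expected in this assay, in either direction, although the range has to stay wide. The estimate means a 1.3-fold lower number from compound 2 to compound 3 (0.10 log units; within the scatter), which is expected to stay within the scatter. For compound 3 the expected value is 12000 nM, with an estimated range from 3000 nM to 30000 nM.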

Compound 3, half-maximal inhibitory concentration: 750 nM
Estimate against measurement, compound 3: 16-fold (1.20 log units) above, outside the stated range (below it).
By their numbers in this assay, from the lowest: compound 3; then compounds 2 and 1 (each within the scatter of the next).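

In this assay, among these compounds, the group on this nitrogen on an aromatic ring can clearly change the read-out: 1-methyl-1H-indol-5-yl brought a large drop from both earlier groups (a 20-fold lower number from compound 2 to compound 3 (1.30 log units; beyond the scatter); a 40-fold lower number from compound 1 to compound 3 (1.60 log units; beyond the scatter)), whereas the only earlier exchange here stayed within the scatter (a 2.0-fold lower number from compound 1 to compound 2 (0.30 log units; within the scatter)). The step from compound 2 also shows that counting heavy atoms is not enough, since the leaving and entering groups have the same count and each has a five-membered ring joined to a six-membered carbon ring; they differ in that the entering group has an aromatic five-membered ring, no hydrogen-bond donor and no double bond outside aromatic rings. Those differences arrive together in a single exchange, so their separate shares cannot be read, and nothing shown here explains the drop.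

The compounds shown leave open whether the methyl of 1-methyl-1H-indol-5-yl contributes, as a hydrogen or an ethyl group in its place would test. They also leave open whether an amine or a carboxylic acid added to this group would keep the lower number.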